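Dropping the Methyl: From Compound 2 to Compound 4

The source may report more compounds than this note shows. Statements on the series, on what has been measured and on what is new or still open speak of the compounds shown alone.

Of the compounds shown here, three sharing one core have been measured in a functional assay on HeLa cells (Homo sapiens) for antiproliferative activity, read by sulforhodamine B assay, with a stated time of 48 h; on this read-out lower numbers stand for stronger inhibition and higher numbers for weaker inhibition. Compound 1 `COc1cc(OC)c2sc(-c3ccc(N/C=C\C(=O)c4cc(OC)c(OC)c(OC)c4)cc3)nc2c1` gives 17800 nM, compound 2 `COc1cc(OC)c2sc(-c3ccc(N/C=C\C(=O)c4ccc(OC)c([N+](=O)[O-])c4)c(C)c3)nc2c1` gives 9390 nM, and compound 3 `COc1cc(OC)c2sc(-c3ccc(N/C=C\C(=O)c4ccc(OC)c(O)c4)c(C)c3)nc2c1` gives 16100 nM. Compound 2 thus sits alongside the other two, with compound 3 and compound 1 both within the usual scatter of it. Among the measured compounds shown here, the only single-point step measured, a 1.7-fold higher number from compound 2 to compound 3 (0.23 log units; within the scatter), shows that swapping the group on the aromatic carbon leaves the read-out essentially unchanged.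

Compound 4 `COc1cc(OC)c2sc(-c3ccc(N/C=C\C(=O)c4ccc(OC)c([N+](=O)[O-])c4)cc3)nc2c1` differs from compound 2 by hydrogen in place of methyl on an aromatic carbon. For the measured compounds named here, no measured step bears on this change: compound 1 and compound 2 differ in more than one place, and their two values show only that they lie within the scatter of each other. With nothing pointing in either direction, compound 4 is expected to move by a 1.1-fold higher number from compound 2 to compound 4 (0.03 log units; within the scatter), that is, by no step beyond the scatter. Compound 4 is therefore estimated at 10000 nM, within a range of 4000 nM to 25000 nM.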

Compound 4, half-maximal inhibitory concentration: 12900 nM
The estimate for compound 4 lay 1.3-fold (0.11 log units) below the measured number; low and high end bracket the measured number.
By their numbers in this assay, from the lowest: compounds 2, 4, 3 and 1 (each within the scatter of the next).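

In this assay, the exchange on the aromatic carbon ortho to a large group and meta to a large group now has a measured step: hydrogen in place of methyl gives a 1.4-fold higher number from compound 2 to compound 4 (0.14 log units; within the scatter) and stays within the scatter. The group on the carbonyl carbon also has its first step that changes one place only, as 4-methoxy-3-nitrophenyl in place of 3,4,5-trimethoxyphenyl gives a 1.4-fold lower number from compound 1 to compound 4 (0.14 log units; within the scatter) and likewise stays within the scatter. No measured evidence is available to explain either step.

Still open, as far as these compounds go, is whether an ethyl, a methoxy or an amine on that aromatic carbon would also stay within the scatter of compound 2. Also open, from the compounds shown here alone, is whether the hydrogen-for-methyl step would read the same with another group on the carbonyl carbon.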